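The source may hold more compounds than are shown below. What is called first, only, known or untested is meant among the compounds shown, and "the series" means these compounds.

Working notes on the series. Compound 1 `O=C(O)c1cc(N2C(=O)C3=C(CCCC3)C2=O)ccc1Cl` gives > 100000 nM in a functional assay on the whole organism with Scenedesmus acutus as the target, with a stated time of 20 h (on this read-out lower numbers stand for stronger inhibition and higher numbers for weaker inhibition), and this value is a limit of the assay. For the measured compounds named here, compound 2 `CCC(C)OC(=O)c1cc(N2C(=O)C3=C(CCCC3)C2=O)ccc1Cl` gives 9770 nM in this assay, the only actual number so far on this read-out. Going by the values given here, the sole measured step is an at least 10-fold lower number from compound 1 to compound 2 (1.01 log units; beyond the scatter), with sec-butyl in place of hydrogen on an oxygen next to a carbonyl group. Compound 3 `CCCCCOC(=O)c1cc(N2C(=O)C3=C(CCCC3)C2=O)ccc1Cl` keeps the shared core and changes only the chain: pentyl in place of sec-butyl on an oxygen next to a carbonyl group. Among the compounds with values here, no measured step compares one chain with another, so the large size of the step to compound 2 does not carry over to this exchange. In this assay, no change beyond the scatter is expected, and the estimate stays close to compound 2 at 9770 nM. The estimated step is a 1.2-fold lower number from compound 2 to compound 3 (0.09 log units; within the scatter). For compound 3 the estimated value is 8000 nM, with an expected range of 2500 nM to 26000 nM.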

Compound 3, half-maximal inhibitory concentration: 5370 nM
Compound 3: middle estimate off by 1.5-fold (0.17 log units), on the high side; measured number inside the range.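

Pentyl in place of sec-butyl on an oxygen next to a carbonyl group gives the only comparison of one chain with another in this assay, and this exchange gives a 1.8-fold lower number from compound 2 to compound 3 (0.26 log units; within the scatter), so the two chains cannot be told apart on this read-out. Pentyl in place of hydrogen at the same oxygen gives an at least 18-fold lower number from compound 1 to compound 3 (1.27 log units; beyond the scatter), so the large step seen with sec-butyl is not confined to that one chain. Compound 1 stands at a limit of the assay, and both steps from it are bounds: the limit of > 100000 nM in this assay, at which 1 of the 3 values shown sits.

Open, from the compounds shown here alone, is whether a longer chain such as octyl, or a chain carrying an amine, would move the number beyond the scatter. Also open, going by these compounds, is whether phenyl on this oxygen would give a step of similar size.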